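Dropping the chloro from the benzyl group of compound 1

A few compounds are considered here, and "the series" means these few. Any claim that something is new, unique, unknown or untested is made for them only; others in the source may bear on it.

Measured so far:
- compound 1, `C=C(Br)C(=O)Nc1ccc(/C=C2\SC(=O)N(Cc3cccc(Cl)c3)C2=O)cc1`: 8900 nM
- compound 2, `CC(C)(C)c1ccc(CN2C(=O)S/C(=C\c3cccc(N)c3)C2=O)cc1`: 145000 nM

Both compounds share a core carrying a benzyl group on one side and a substituted phenyl ring on the other. In a functional assay on HeLa cells (Homo sapiens) for cytotoxicity, read by cell counting, with a stated time of 4 days (a lower number here means a stronger inhibitor, a higher number a weaker inhibitor), compound 1 gives 8900 nM, the lowest of the two numbers shown, and compound 2, which differs from it in several places, gives 145000 nM, a gap well beyond the usual scatter. Going by the values given here, no pair of measured compounds differs in a single place, so no step has been measured directly.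

Compound 3, `C=C(Br)C(=O)Nc1ccc(/C=C2\SC(=O)N(Cc3ccccc3)C2=O)cc1`, is the next compound to be measured. It differs from compound 1 in one place only: hydrogen in place of chloro on an aromatic carbon. In other words the 3-chlorobenzyl group becomes a plain benzyl group while the rest of the molecule is kept.

Among the compounds with values here, nothing among the measured compounds shows what this single change does. The estimate for compound 3 therefore leans on compound 1, with a step of a 1.7-fold higher number from compound 1 to compound 3 (0.23 log units; within the scatter) expected to be small, in the direction of a somewhat higher number, and possibly not beyond the scatter at all. Compound 3 is expected to give about 15000 nM, in the range from 5000 nM to 45000 nM.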

Compound 3, half-maximal inhibitory concentration: 1000 nM
Compound 3: the middle estimate sits 15-fold (1.18 log units) above what was measured; measured number outside the range, below it.
By their numbers in this assay, from the lowest: compound 3; then compound 1; then compound 2.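

Going by these compounds alone, this is the first single change measured in this assay, and it shows that this position on the benzyl ring matters: with the rest of the molecule kept, putting hydrogen in place of chloro gives an 8.9-fold lower number from compound 1 to compound 3 (0.95 log units; beyond the scatter). The chloro of the 3-chlorobenzyl group is therefore not needed for a low number here, and the plain benzyl group of compound 3 does better, so the loss of one heavy atom moves the result beyond the usual scatter. The earlier comparison of compound 1 with compound 2 could not show this, since those two differ in several places at once.

Going by these compounds, whether another group on this aromatic carbon, such as fluoro, methoxy or a carboxylic acid, would give a lower or a higher number than hydrogen stays open, as does whether the same step would appear with a different group on the substituted phenyl ring on the other side of the core. Nothing measured here explains why this step goes in this direction.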